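This account rests on a few compounds, and the source may have more. Where it says the series, first, only, none or still open, it means among the compounds named here.

Measured compounds:
compound 1, `Cc1ccc(S(=O)(=O)Nc2ccc(-c3ccccc3N(C)C)nn2)cc1` — 4.5 nM
compound 2, `Cc1ccc(S(=O)(=O)Nc2ccc(-c3ccccc3N3CCN(C)CC3)nn2)cc1` — a limit only, > 100 nM

In an assay on mitochondria from liver for inhibition of kynurenine 3-monooxygenase (Mus musculus), read by LC-MS, with stated times of 5 min and 30 min (on this read-out higher numbers stand for weaker inhibition and lower numbers for stronger inhibition), compound 1 gives 4.5 nM. For compound 2 the assay returns no number but a limit, > 100 nM. The step of an at least 22-fold higher number from compound 1 to compound 2 (1.34 log units; beyond the scatter) therefore puts compound 2 at the weak end of the two values shown, sitting at the limit of > 100 nM in this assay, at which 1 of the 2 values shown sits.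

Compound 3, `COc1ccccc1-c1ccc(NS(=O)(=O)c2ccc(C)cc2)nn1`, is not yet measured. It differs from compound 2 by methoxy in place of 4-methylpiperazin-1-yl on an aromatic carbon. Going by the values given here, the one measured step that bears on this change is an at least 22-fold higher number from compound 1 to compound 2 (1.34 log units; beyond the scatter), which runs in the opposite direction: with the dimethylamino on that carbon, compound 1 gave the stronger number, and the 4-methylpiperazin-1-yl carried compound 2 to the limit. Taking the 4-methylpiperazin-1-yl away again is thus expected to lower the number beyond the scatter, a step estimated as an at least 10-fold lower number from compound 2 to compound 3 (1.00 log units; beyond the scatter). Compound 3 is expected near 10 nM, within 3 nM to 40 nM.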

Compound 3, half-maximal inhibitory concentration: 36.5 nM
Compound 3: middle estimate off by 3.7-fold (0.56 log units), on the low side; measured number inside the range.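

Replacing 4-methylpiperazin-1-yl with methoxy on this aromatic carbon lowers the number, with an at least 2.7-fold lower number from compound 2 to compound 3 (0.43 log units; beyond the scatter), so the weak end of the series does not extend to every group at this place. Compound 2 is a limit, so that step gives only a bound: the limit of > 100 nM in this assay, at which 1 of the 3 values shown sits.

Methoxy does not match dimethylamino in this assay, with an 8.1-fold higher number from compound 1 to compound 3 (0.91 log units; beyond the scatter), so the number at this carbon also shifts between the replacements of 4-methylpiperazin-1-yl, and compound 1 stays the strongest of the three.

From the compounds shown here alone, whether the difference follows the atom attached to this carbon or the size of the group stays open; ethoxy, a primary amine or pyrrolidine at this place would separate those readings. Also open, going by these compounds, is whether the same order holds with a group other than the methylphenyl on the sulfonyl.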